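Moving the carboxyl and restoring the branch: compound 4

A few compounds are considered here, and "the series" means these few. Any claim that something is new, unique, unknown or untested is made for them only; others in the source may bear on it.

Compound 3 `O=C(O)c1ccccc1OCc1ccc(OCc2c(-c3c(Cl)cccc3Cl)noc2C2CC2)nc1C(F)(F)F` gives 1710 nM in a functional assay on HEK293 cells for agonist activity at Bile acid receptor (Homo sapiens) (on this read-out higher numbers stand for an effect only at larger amounts of compound and lower numbers for an effect already at smaller amounts), the highest number of the three measured; compound 1 `CC(Nc1ccc(C(=O)O)cc1)c1ccc(OCc2c(-c3c(Cl)cccc3Cl)noc2C2CC2)nc1C(F)(F)F` gives 333 nM and compound 2 `CC(c1ccc(OCc2c(-c3c(Cl)cccc3Cl)noc2C2CC2)nc1C(F)(F)F)N(C)c1ccc(C(=O)O)cc1` gives 208 nM. Compound 4 `CC(Oc1cccc(C(=O)O)c1)c1ccc(OCc2c(-c3c(Cl)cccc3Cl)noc2C2CC2)nc1C(F)(F)F` differs from compound 3 in one place: 1-(3-carboxyphenoxy)ethyl in place of (2-carboxyphenoxy)methyl on an aromatic carbon. Among the compounds with values here, the only step that touches this region is a 5.1-fold higher number from compound 1 to compound 3 (0.71 log units; beyond the scatter), where the acid-bearing arm was rebuilt; the branching methyl on the arm returns in compound 4, while the acid sits in a new ring position for which no measured pair exists. The step of a 1.6-fold lower number from compound 1 to compound 2 (0.20 log units; within the scatter) lies elsewhere and offers little guidance. A lower number is therefore expected for compound 4, of modest size, a 2.9-fold lower number from compound 3 to compound 4 (0.45 log units; beyond the scatter), estimated at 600 nM with a range from 200 nM to 2500 nM.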

Compound 4, half-maximal effective concentration: 107 nM
Beside the measured number, compound 4's estimate is 5.6-fold (0.75 log units) above it; the whole stated range lies above it.
By their numbers in this assay, from the lowest: compounds 4, 2 and 1 (each within the scatter of the next, the first and the last beyond it); then compound 3.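

In this assay, the step of a 16-fold lower number from compound 3 to compound 4 (1.20 log units; beyond the scatter) is large, but it combines the branching methyl with a new acid position, so the two changes cannot be separated. With the 3-carboxyphenoxy arm on the branched carbon, an oxygen link works at least as well as the nitrogen links, with a 3.1-fold lower number from compound 1 to compound 4 (0.49 log units; beyond the scatter) and with a 1.9-fold lower number from compound 2 to compound 4 (0.29 log units; within the scatter) as well. Nothing measured here explains these differences. Still open, going by these compounds, is whether the methyl or the acid position accounts for the large step. Also open, on these data alone, is how a longer chain in the arm, or a nitrile in place of the carboxylic acid, would read out.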